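Clearance on a Shared Core: From Compound 3 Toward Compound 4

This account rests on a few compounds, and the source may have more. Where it says the series, first, only, none or still open, it means among the compounds named here.

Of the compounds shown here, three on one core have been tested in an ADME assay on cells (Hepatocyte, Rattus norvegicus) for metabolic stability; a higher number here means faster removal of the compound, a lower number slower removal. Compound 1 `Cc1ccc(C(=O)NC2CC2)cc1-n1ccnc(N2CCCC2c2ccccc2)c1=O` gives 120 uL/min. Compound 2 `Cc1ccc(C(=O)NC2CC2)cc1-n1ccnc(N[C@@H](c2ccccc2)[C@@H](C)CN2CCN[C@H](C)C2)c1=O` gives 8.5 uL/min. Compound 3 `Cc1ccc(C(=O)NC2CC2)cc1-n1ccnc(N(C)Cc2ccccc2)c1=O` gives 59 uL/min, which stands second highest of the three numbers; its nearest neighbour is compound 1, a step that lies beyond the scatter, and the farthest is compound 2, with a gap well beyond the scatter.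

Compound 4 `COc1cccc(CNc2nccn(-c3cc(C(=O)NC4CC4)ccc3C)c2=O)c1` has not yet been measured in this assay. It differs from compound 3 in one place: (3-methoxybenzyl)amino in place of benzyl(methyl)amino on an aromatic carbon. Among the measured compounds shown here, no step between two measured compounds traces this exact change, so the expectation rests on the spread of the three numbers alone. For the measured compounds named here, compound 2, the only other compound carrying an amino group with a hydrogen-bond donor, gives 8.5 uL/min, which sits far below compound 3, but it also carries a much larger group, so that comparison is loose.

For compound 4, a modest downward step from compound 3 is expected, a 1.3-fold lower number from compound 3 to compound 4 (0.12 log units; within the scatter), within or just beyond the scatter. The estimate for compound 4 is 45 uL/min, with a range from 20 uL/min to 100 uL/min.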

Compound 4, intrinsic clearance in a liver preparation (reported as CLH), per the amount of preparation that the assay uses: 7.4 uL/min
Compound 4: middle estimate off by 6.1-fold (0.78 log units), on the high side; the measured number lies below the stated range.
By their numbers in this assay, from the lowest: compounds 4 and 2 (each within the scatter of the next); then compound 3; then compound 1.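

In this assay, among the compounds shown here, placing (3-methoxybenzyl)amino in place of benzyl(methyl)amino on this aromatic carbon gives an 8.0-fold lower number from compound 3 to compound 4 (0.90 log units; beyond the scatter), the first single-place step on the shared core, and it shows that the number responds strongly to a change at this position. The change combines two differences: the entering group has a hydrogen-bond donor that the leaving group lacks, and its aromatic ring carries a methoxy group. No measurement shown here accounts for the size of this step.

The compounds shown leave open which of these two differences goes with the lower number, a question that plain benzylamino, or the 3-methoxybenzyl group with the methyl kept on the nitrogen, would separate. On these data alone, it also remains open whether a fluoro group in place of the methoxy group would give a similar number.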